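A Methoxy Group Added to a Starting Point Beyond Reach

The source may hold more compounds than are shown below. What is called first, only, known or untested is meant among the compounds shown, and "the series" means these compounds.

For the measured compounds named here, compound 3 `C/C(=N\OCC(=O)Nc1ccccc1)C1=C(O)c2ccccc2S(=O)(=O)N1C` is one of three compounds measured in a functional assay on THP-1 cells (Homo sapiens) for inhibition, read by ELISA, with stated times of 2 h and 48 h; on this read-out lower numbers stand for stronger inhibition and higher numbers for weaker inhibition. In this assay compound 3 gives > 20000 nM, which is a limit of the assay and not a number. Compound 1 `CCOC1=C(/C(C)=N/OCC(=O)Nc2ccccc2)N(C)S(=O)(=O)c2ccccc21` likewise gives a limit in this assay, namely > 20000 nM. Compound 2 `CCOC1=C(/C(C)=N/OCC(=O)Nc2c(F)cccc2F)N(C)S(=O)(=O)c2ccccc21` gives > 20000 nM in this assay, again a limit rather than a number. Going by the values given here, because of the limit of > 20000 nM in this assay, at which 3 of the 3 values shown sit, the two measured steps, a step that the two limits leave unreadable from compound 1 to compound 2 and a step that the two limits leave unreadable from compound 1 to compound 3, cannot be read in size, and no measured step shows any direction. Compound 4 `COc1ccc(NC(=O)CO/N=C(\C)C2=C(O)c3ccccc3S(=O)(=O)N2C)cc1` differs from compound 3 by methoxy in place of hydrogen on an aromatic carbon. Among the compounds with values here, neither measured step involves a methoxy group, so neither bears on this change, and the data give no size of step to expect in this assay beyond the scatter in either direction. Compound 4 is therefore expected to remain near the limit, at about 30000 nM, within a range from 8000 nM to 100000 nM. The step that the limit leaves unreadable from compound 3 to compound 4 that this estimate means is expected to stay within the scatter.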

Compound 4, half-maximal inhibitory concentration: > 20000 nM
Compound 4 gave a limit, no number; the forecaster's own chance of this, stated with the estimate: 85%; the middle value does not contradict the limit.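

No new step can be read, since compound 3 and compound 4 both stand at a limit and the change from hydrogen to methoxy has no readable size: the limit of > 20000 nM in this assay, at which 4 of the 4 values shown sit.

The compounds shown leave open which structural change, if any, would give a real number instead of a limit.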